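The compounds below may be only part of what the source reports. "The series", "measured", "known", "first", "only" and "open" are said of these compounds alone.

Compound 3 `COc1ccc(CNc2nc(SC)nc3ccccc23)cc1` stands at the edge of what the assay reports: in a functional assay on HT-29 cells (Homo sapiens) for cytotoxicity, read by MTT assay, with a stated time of 72 h (a higher number here means a weaker inhibitor of growth, a lower number a stronger inhibitor of growth), compound 3 gives > 100000 nM, which is a limit and not a number. Compound 1 `COc1ccc(CNc2nc([Se]C)nc3ccccc23)cc1` likewise returns a limit, > 100000 nM. The step that the two limits leave unreadable from compound 1 to compound 3 is unreadable because of the limit of > 100000 nM in this assay, at which 2 of the 3 values shown sit. Going by the values given here, the one measured number comes from compound 2 `Sc1nc(NCc2ccccc2)c2ccccc2n1`, which gives 63500 nM, a value rather than a limit. Compound 4 `COc1ccc(CNc2nc(S)nc3ccccc23)cc1` differs from compound 3 by hydrogen in place of methyl on a sulfur. Among the compounds with values here, no measured step mirrors this change, so its size is uncertain. Compound 4 is expected to move by an at least 1.3-fold lower number from compound 3 to compound 4 (0.12 log units; that floor lies within the scatter), toward a readable number. Compound 4 is estimated at 75000 nM, between 30000 nM and 180000 nM, an expectation guided by compound 2 and its 63500 nM.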

Compound 4, concentration for total growth inhibition: 28600 nM
Beside the measured number, compound 4's estimate is 2.6-fold (0.42 log units) above it; the measured number lies below the stated range.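

In this assay, going by these compounds alone, hydrogen in place of methyl on the sulfur gives the first readable number for a methoxy compound: an at least 3.4-fold lower number from compound 3 to compound 4 (0.54 log units; beyond the scatter). The selenium compound shows a similar floor, an at least 3.4-fold lower number from compound 1 to compound 4 (0.54 log units; beyond the scatter), so the sulfanyl group reads where both methylated groups stay at a limit: the limit of > 100000 nM in this assay, at which 2 of the 4 values shown sit. With sulfanyl kept, methoxy in place of hydrogen on an aromatic carbon also lowers the number: a 2.2-fold lower number from compound 2 to compound 4 (0.35 log units; beyond the scatter).

Going by these compounds, the step between compound 1 and compound 3 cannot be read, and the full size of the steps starting from limits stays unknown. On these data alone, whether an ethyl group on the sulfur, or an amine in place of the sulfanyl group, would keep this number remains open.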